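Notes on removing the aryl methyl of compound 2

The source may report more compounds than this note shows. Statements on the series, on what has been measured and on what is new or still open speak of the compounds shown alone.

compound 1 `O=C(Nc1ccc(Oc2ccnc3[nH]ccc23)cc1)c1cc(-c2ccc(C(F)(F)F)cc2)ccn1`: in a functional assay on A549 cells (Homo sapiens) for cytotoxicity, read by MTT assay, with a stated time of 72 h (on this read-out higher numbers stand for weaker inhibition and lower numbers for stronger inhibition), compound 1 gives 3950 nM
compound 2 `Cc1cccc(-c2ccnc(C(=O)Nc3ccc(Oc4ccnc5[nH]ccc45)cc3)c2)c1`: in this assay compound 2 gives 7010 nM

Among the compounds with values here, compound 2 holds the highest of the two numbers in this assay; the only measured step, a 1.8-fold higher number from compound 1 to compound 2 (0.25 log units; within the scatter), sets 3-methylphenyl in place of 4-(trifluoromethyl)phenyl on an aromatic carbon and stays within the scatter.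

Compound 3 `O=C(Nc1ccc(Oc2ccnc3[nH]ccc23)cc1)c1cc(-c2ccccc2)ccn1` differs from compound 2 by hydrogen in place of methyl on an aromatic carbon: methyl leaves, hydrogen enters, on an aromatic carbon of a six-membered aromatic ring of carbon only, meta to a large group. Within the data shown here, no measured step removes a methyl; the one step touching this aryl, a 1.8-fold higher number from compound 1 to compound 2 (0.25 log units; within the scatter), lay within the scatter. In this assay no step beyond the scatter is therefore expected for compound 3, a 1.2-fold lower number from compound 2 to compound 3 (0.07 log units; within the scatter). Compound 3 is estimated at 6000 nM, range 2500 nM to 15000 nM.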

Compound 3, half-maximal inhibitory concentration: 2920 nM
Estimate against measurement, compound 3: 2.1-fold (0.31 log units) above; the range from low to high includes it.
By their numbers in this assay, from the lowest: compounds 3, 1 and 2 (each within the scatter of the next, the first and the last beyond it).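

In this assay, within the data shown here, hydrogen in place of methyl gives the first step at this aryl beyond the scatter, though a modest one (a 2.4-fold lower number from compound 2 to compound 3 (0.38 log units; beyond the scatter)), so 3-methylphenyl and phenyl can be told apart here. Hydrogen in place of trifluoromethyl stays within the scatter (a 1.4-fold lower number from compound 1 to compound 3 (0.13 log units; within the scatter)), so phenyl and the trifluoromethyl-bearing aryl of compound 1 cannot be told apart. Nothing measured on these compounds bears on the origin of the methyl step.

Open, on these data alone, is whether an ethyl, a methoxy, an amine or a carboxylic acid on this same carbon would move the number as methyl does.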